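The compounds below may be only part of what the source reports. "The series", "measured", "known", "first", "only" and "open" are said of these compounds alone.

Measured so far:
- compound 1, `CCCN(CC1CC1)C(=O)c1c(C)nc2n(-c3c(C)cc(C)cc3C)c(Cl)cn12`: 61 nM
- compound 2, `C=CCN(CC=C)Cc1c(C(F)(F)F)nc2n(-c3c(C)cc(C)cc3C)c(Cl)cn12`: 13 nM
- compound 3, `Cc1cc(C)c(-n2c(Cl)cn3c(CN(CCC(F)(F)F)Cc4cccc(F)c4)c(C(F)(F)F)nc23)c(C)c1`: 49 nM

The three compounds share a core and were tested in an assay on cells for displacement of a labelled ligand from corticotropin-releasing factor receptor 1 (Homo sapiens), with a stated time of 100 min; on this read-out lower numbers stand for stronger inhibition and higher numbers for weaker inhibition. Compound 2 gives the lowest number of the three, 13 nM, and both other values stand higher by margins beyond the usual scatter: compound 3 gives 49 nM and compound 1 gives 61 nM. Within this small set, compound 2 is therefore the most potent binder.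

Compound 4, `Cc1cc(C)c(-n2c(Cl)cn3c(CN(C)Cc4ccccc4)c(C(F)(F)F)nc23)c(C)c1`, has not yet been measured in this assay. It keeps everything of compound 2 except one group: benzyl(methyl)amino in place of diallylamino on a saturated chain carbon bound to an aromatic carbon. Among the measured compounds shown here, no pair of the measured compounds differs in only this one place, so no measured step tells how such a swap of the amine substituents plays out. Compound 3 carries a different amine on the same chain carbon and sits higher than compound 2, which hints that changes here are not neutral, but compound 3 alters two substituents at once.

A modest step toward weaker binding, a 2.3-fold higher number from compound 2 to compound 4 (0.36 log units; beyond the scatter), is expected from compound 2 to compound 4. Compound 4 is estimated at 30 nM, with a range from 8 nM to 120 nM.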

Compound 4, inhibition constant: 160 nM
Compound 4: middle estimate off by 5.3-fold (0.73 log units), on the low side, and the stated range ends below it.
By their numbers in this assay, from the lowest: compound 2; then compounds 3 and 1 (each within the scatter of the next); then compound 4.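

In this assay, among the compounds shown here, replacing diallylamino with benzyl(methyl)amino on a saturated chain carbon bound to an aromatic carbon is a large step (a 12-fold higher number from compound 2 to compound 4 (1.09 log units; beyond the scatter)), which shows that binding depends strongly on the amine at this position, something no single-place comparison among the earlier compounds could show. The change brings in a six-membered aromatic ring of carbon only and removes two double bonds outside aromatic rings, while the counts of hydrogen-bond donors and acceptors and the absence of net charge stay the same. Nothing available here accounts for the size of this step.

The compounds shown leave open whether the loss follows the benzyl or the methyl part of the new amine. They also leave open how dipropylamino or morpholine would read on this same chain carbon.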